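Swapping a Methyl for a Fluoro on the Fused Ring

The source may hold more compounds than are shown below. What is called first, only, known or untested is meant among the compounds shown, and "the series" means these compounds.

Compound 3 `Cc1ccc2oc(-c3ccc(NC(=O)CCl)cc3)nc2c1` was tested in a functional assay on MCF7 cells (Homo sapiens) for cytotoxicity, read by MTT assay, with a stated time of 24 h (on this read-out higher numbers stand for weaker inhibition and lower numbers for stronger inhibition), where compound 3 gives 4620 nM. Of the two numbers recorded on this assay, this is the lowest. The nearest neighbour is compound 1 `Cc1ccc2oc(-c3ccc(NC(=O)CN4CCN(CCN(C)C)CC4)cc3)nc2c1`, which in this assay gives 23700 nM, a gap that lies beyond the usual scatter of repeated measurements. Compound 2 `Cc1cc(-c2nc3cc(F)ccc3o2)ccc1NC(=O)CCl` reaches only a limit of the assay: in this assay compound 2 gives > 100000 nM. That value is the limit of > 100000 nM in this assay, at which 1 of the 3 values shown sits.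

Compound 4 `O=C(CCl)Nc1ccc(-c2nc3cc(F)ccc3o2)cc1` differs from compound 3 in a single place: fluoro in place of methyl on an aromatic carbon. Going by the values given here, no measured pair shows exactly this swap on its own. Compound 2 also carries the fluoro but differs from compound 4 in more than one place, so it offers no clean guide. A modest loss of potency is expected, with the step from a 2.6-fold higher number from compound 3 to compound 4 (0.41 log units; beyond the scatter) as the estimate. Compound 4 is therefore expected to give about 12000 nM, within a range from 3000 nM to 60000 nM.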

Compound 4, half-maximal inhibitory concentration: 3260 nM
For compound 4 the middle estimate is 3.7-fold (0.57 log units) above the measured one; the range from low to high includes it.
By their numbers in this assay, from the lowest: compounds 4 and 3 (each within the scatter of the next); then compound 1. At a limit, above all of these: compound 2.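

Going by these compounds alone, the swap of fluoro in place of methyl on an aromatic carbon of the fused ring is the first clean test of this position, and in this assay it gives a 1.4-fold lower number from compound 3 to compound 4 (0.15 log units; within the scatter), so the two groups cannot be told apart here. A different change, the loss of a methyl group from an aromatic carbon elsewhere in the molecule, weighs far more: an at least 30-fold lower number from compound 2 to compound 4 (1.48 log units; beyond the scatter). That step is only a bound, as compound 2 stands at a limit of the assay and not at a number: the limit of > 100000 nM in this assay, at which 1 of the 4 values shown sits.

From the compounds shown here alone, whether this position accepts anything beyond methyl and fluoro, such as a plain hydrogen, a chlorine or a methoxy group, stays open. Also open, going by these compounds, is whether the swap behaves the same way when the chloroacetyl end gives way to the longer amine chain of compound 1.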